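Trading a Thiophenecarbonyl Group for Hydrogen on Compound 1

The source may hold more compounds than are shown below. What is called first, only, known or untested is meant among the compounds shown, and "the series" means these compounds.

Compound 1 `Nc1nn(C(=O)c2cccs2)c(N)c1/N=N/c1ccc(O)cc1` was tested in a functional assay on RPMI-8226 cells (Homo sapiens) for cytotoxicity, read by fluorescence, with a stated time of 72 h; a higher number here means a weaker inhibitor, a lower number a stronger inhibitor. In this assay compound 1 gives only a limit, > 100000 nM, and not a measured number. Two related compounds give context. Compound 2 `Nc1n[nH]c(N)c1/N=N/c1cc[n+]([O-])cc1` also reaches only a limit in this assay, > 100000 nM. Compound 3 `Cn1nc(N)c(/N=N/c2ccncc2)c1N` gives a measured value in this assay of 50000 nM. Compound 1 therefore sits at the weak end of the numbers shown, where most of them gather, as the limit of > 100000 nM in this assay, at which 2 of the 3 values shown sit, makes plain.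

Compound 4 `Nc1n[nH]c(N)c1/N=N/c1ccc(O)cc1` differs from compound 1 in one place: hydrogen in place of (thiophen-2-yl)carbonyl on an aromatic nitrogen. Among the measured compounds shown here, no pair of measured compounds differing in only one place is available, so the size of this step has to be guessed. Compound 2 carries hydrogen on an aromatic nitrogen as compound 4 does, and compound 3 carries a methyl there; neither points toward a strong inhibitor. In this assay the expected step is a number no higher from compound 1 to compound 4 (the limit leaves the size open), which stays within the usual scatter. Compound 4 is estimated at 100000 nM, with a range from 30000 nM to 300000 nM, and a limit rather than a number is the more likely report.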

Compound 4, half-maximal inhibitory concentration: 24900 nM
Compound 4: middle estimate off by 4.0-fold (0.60 log units), on the high side; measured number outside the range, below it.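

Trading the (thiophen-2-yl)carbonyl on the aromatic nitrogen for hydrogen gives an at least 4.0-fold lower number from compound 1 to compound 4 (0.60 log units; beyond the scatter) in this assay, the first direct sign that a change at this position can shift the read-out. Compound 1 gives only a limit, > 100000 nM. The step is therefore a minimum rather than a measured size, and such limits are common among these few compounds: the limit of > 100000 nM in this assay, at which 2 of the 4 values shown sit.

The compounds shown compare only hydrogen and (thiophen-2-yl)carbonyl at this nitrogen with everything else held the same, so they do not tell whether the bulk of the departing group, its thiophene ring or its carbonyl matters most. As far as these compounds go, how a smaller acetyl group, a benzoyl group or a longer alkyl chain would read at this nitrogen on the core of compound 4 remains open.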